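The source may report more compounds than this note shows. Statements on the series, on what has been measured and on what is new or still open speak of the compounds shown alone.

Compound 1 `C#CCNC1CCc2c(OCCc3cc(NC(C)=O)ccc3Cl)cccc21` gives 590 nM in an assay on cells for inhibition of Amine oxidase [flavin-containing] B (Homo sapiens), read by fluorescence and Amplex Red, with stated times of 30 min and 15 min; on this read-out lower numbers stand for stronger inhibition and higher numbers for weaker inhibition. Compound 2 `C#CCNC1CCc2c(OCCc3cc(NC(=O)c4cccc(F)c4)ccc3Cl)cccc21` reaches only a limit in this assay, > 20000 nM, which is the limit of > 20000 nM in this assay, at which 1 of the 2 values shown sits. The step of an at least 33-fold higher number from compound 1 to compound 2 (1.53 log units; beyond the scatter) is therefore known only as a lower bound. Compound 3 `C#CCNC1CCc2c(OCCc3cc(NC(=O)c4ccc(F)cc4)ccc3Cl)cccc21` differs from compound 2 by 4-fluorophenyl in place of 3-fluorophenyl on a carbonyl carbon. Within the data shown here, no measured step bears on moving the fluorine within the phenyl ring; the only known step concerns the acetyl-to-benzoyl change. Compound 3 is thus expected to stay near compound 2, with a step that the limit leaves unreadable from compound 2 to compound 3. The estimate for compound 3 is 25000 nM, in the range 5000 nM to 100000 nM.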

Compound 3, half-maximal inhibitory concentration: 5100 nM
Compound 3: middle estimate off by 4.9-fold (0.69 log units), on the high side; measured number inside the range.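

In this assay, 4-fluorophenyl in place of 3-fluorophenyl on the carbonyl carbon gives an at least 3.9-fold lower number from compound 2 to compound 3 (0.59 log units; beyond the scatter), so the position of the fluorine on this phenyl ring matters, and the aryl amide is not uniformly poor. The size of that step remains a lower bound, as compound 2 stands only at a limit: the limit of > 20000 nM in this assay, at which 1 of the 3 values shown sits.

Replacing methyl remains costly even with 4-fluorophenyl, with an 8.6-fold higher number from compound 1 to compound 3 (0.94 log units; beyond the scatter).

On these data alone, it remains open whether plain phenyl on the carbonyl carbon would sit with compound 2 or compound 3. As far as these compounds go, it also remains open whether ethyl or cyclopropyl would keep the value of compound 1, 590 nM.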